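A few compounds are considered here, and "the series" means these few. Any claim that something is new, unique, unknown or untested is made for them only; others in the source may bear on it.

Compound 2 `Cc1cccc(C)c1-c1cccc(COc2ccc(S(=O)(=O)CC(=O)O)cc2)c1` shows the lowest of the three numbers in a functional assay on CHO cells for agonist activity at Free fatty acid receptor 1 (Homo sapiens), read by FLIPR and calcium flux (on this read-out higher numbers stand for an effect only at larger amounts of compound and lower numbers for an effect already at smaller amounts), with 66.1 nM. Compound 3 `Cc1cc(OCC(C)C)cc(C)c1-c1cccc(COc2ccc(S(=O)(=O)CC(=O)O)cc2)c1` gives 95.5 nM, and the gap between them, a 1.4-fold higher number from compound 2 to compound 3 (0.16 log units; within the scatter), lies within the scatter, so no order between compound 2 and compound 3 can be read from it. Compound 1 `Cc1cccc(C)c1-c1cccc(COc2ccc(SCC(=O)O)cc2)c1` gives 195 nM, and the step of a 3.0-fold lower number from compound 1 to compound 2 (0.47 log units; beyond the scatter) is the only one beyond the scatter.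

Compound 4 `N#Cc1ccccc1-c1cccc(COc2ccc(S(=O)(=O)CC(=O)O)cc2)c1` has not yet been measured. It differs from compound 2 by 2-cyanophenyl in place of 2,6-dimethylphenyl on an aromatic carbon. Neither measured step touches this part of the molecule: the step from compound 1 to compound 2 changes the sulfur-bearing group, and the step from compound 2 to compound 3 adds isobutoxy on the 2,6-dimethylphenyl ring, which itself is replaced here. The data therefore give no direct guide, and the expected step of a 2.0-fold higher number from compound 2 to compound 4 (0.29 log units; within the scatter) is set as a modest rise that may well fall within the scatter. For compound 4 the estimate is 130 nM, with a range from 40 nM to 450 nM.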

Compound 4, half-maximal effective concentration in the Free fatty acid receptor 1 assay: 457 nM
Estimate against measurement, compound 4: 3.5-fold (0.55 log units) below; the measured number lies above the stated range.
By their numbers in the Free fatty acid receptor 1 assay, from the lowest: compounds 2 and 3 (each within the scatter of the next); then compound 1; then compound 4.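

Up to this point, every measured compound carried the 2,6-dimethylphenyl group, so nothing showed how the Free fatty acid receptor 1 assay responds to a change at this position. Replacing it with 2-cyanophenyl gives a 6.9-fold higher number from compound 2 to compound 4 (0.84 log units; beyond the scatter), so this position is not indifferent to the change, even though the heavy-atom count stays the same and the nitrile adds a hydrogen-bond acceptor. No evidence is available to explain this rise.

Going by these compounds alone, in a physicochemical assay for lipophilicity, using the shake flask method, in phosphate buffer, measured as octanol-water partition, with a stated time of 24 h, at pH 7.4, tested at 100 uM (a higher number here means a more lipophilic compound, a lower number a more polar compound), compound 2 gives 2.49, but compound 4 stands as "not determined" (no result reported), with no result reported, so no step between them can be read. On these data alone, it remains open whether the rise follows from the nitrile or from the loss of the two methyl groups, and what a single methyl group or a methoxy group would give at this position.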